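The source may hold more compounds than are shown below. What is called first, only, known or untested is meant among the compounds shown, and "the series" means these compounds.

Measured so far:
- compound 1 `COc1cc2c(cc1O)CN(CCCCNC(=O)c1ccc(I)cc1)CC2`: 1500 nM in an assay on cells for displacement of a labelled ligand from D(4) dopamine receptor (Homo sapiens); on this read-out higher numbers stand for weaker inhibition and lower numbers for stronger inhibition
- compound 2 `COc1cc2c(cc1O)CN(CCCCNC(=O)c1ccnc3ccccc13)CC2`: 410 nM in this assay

Compound 1 stands highest of the two numbers in this assay; the only step shown, a 3.7-fold lower number from compound 1 to compound 2 (0.56 log units; beyond the scatter), is modest but beyond the scatter. Compound 3 `COc1cc2c(cc1O)CN(CCCCNC(=O)c1ccc(-c3ccccc3)cc1)CC2` differs from compound 1 by phenyl in place of iodo on an aromatic carbon. Among the measured compounds shown here, no measured step matches this change; the step from compound 1 to compound 2 is the only one that bears on it, and it also enlarges the amide substituent. Compound 3 is therefore expected to show a modest lowering, a 2.1-fold lower number from compound 1 to compound 3 (0.33 log units; beyond the scatter), to an estimated 700 nM, within 200 nM to 2500 nM.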

Compound 3, inhibition constant: 720 nM
For compound 3 the middle estimate is 1.0-fold (0.01 log units) below the measured one; the range from low to high includes it.
By their numbers in this assay, from the lowest: compounds 2 and 3 (each within the scatter of the next); then compound 1.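

Earlier, the whole group on the carbonyl carbon was swapped; here a single substituent changes, on an aromatic carbon para to a large group. In this assay, phenyl in place of iodo gives a 2.1-fold lower number from compound 1 to compound 3 (0.32 log units; beyond the scatter), so this position accepts a second aromatic ring, six heavy atoms in place of one, and inhibition still strengthens modestly. No available evidence bears on this step. Open, from the compounds shown here alone, is whether the ring itself matters or size alone, and how an amine or a carboxylic acid at this position would read.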